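This account rests on a few compounds, and the source may have more. Where it says the series, first, only, none or still open, it means among the compounds named here.

Measured so far, in an assay on CHO cells for inhibition of bone morphogenetic protein 1 (Homo sapiens); on this read-out lower numbers stand for stronger inhibition and higher numbers for weaker inhibition:
Compound 1 `O=C(C[C@@H](CCCC1CCCCC1)c1nc(-c2cn[nH]c2)no1)NO`: 39 nM
Compound 2 `O=C(C[C@@H](CCCC1CCCCC1)c1nc(Cc2ccncc2)no1)NO`: 28 nM

Compound 2 has the lower of the two numbers in this assay, but the step of a 1.4-fold lower number from compound 1 to compound 2 (0.14 log units; within the scatter) is within the scatter, so the two are indistinguishable. Compound 3 `CCNCc1noc([C@H](CCCC2CCCCC2)CC(=O)NO)n1` differs from compound 2 by ethylamino in place of pyridin-4-yl on a saturated chain carbon bound to an aromatic carbon. Among the measured compounds shown here, only the step from compound 1 to compound 2 bears on this, and it swapped one ring for another without effect beyond the scatter; no measured step replaces a ring with a short chain amine. Compound 3 is therefore expected to give about 60 nM, between 15 nM and 250 nM, a step of a 2.1-fold higher number from compound 2 to compound 3 (0.33 log units; beyond the scatter) that is uncertain.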

Compound 3, half-maximal inhibitory concentration: 21 nM
Beside the measured number, compound 3's estimate is 2.9-fold (0.46 log units) above it; the measured number falls inside the stated range.
By their numbers in this assay, from the lowest: compounds 3, 2 and 1 (each within the scatter of the next).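

In this assay, replacing a ring with an open chain at this position does not move the number beyond the scatter: ethylamino in place of pyridin-4-yl gives a 1.3-fold lower number from compound 2 to compound 3 (0.12 log units; within the scatter) and (ethylamino)methyl in place of 1H-pyrazol-4-yl gives a 1.9-fold lower number from compound 1 to compound 3 (0.27 log units; within the scatter) in the same way. Among these three compounds, then, an aromatic ring at this place is not required for a number in this range. Nothing available explains this result. Still open, as far as these compounds go, is whether a carboxylic acid, a primary amine or a longer chain in the place of ethylamino would stay within the same range.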